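The compounds below may be only part of what the source reports. "The series", "measured", "known", "first", "only" and "open" are said of these compounds alone.

Compound 1 `CN1CCN(c2ccc(-c3cc4c(N5CCN(C(=O)Nc6ccc(C#N)cc6)CC5)ncnc4s3)cc2)CC1`: 5010 nM
Compound 2 `CN1CCN(c2ccc(-c3cc4c(N5CCN(C(=O)Nc6ccccc6F)CC5)ncnc4s3)cc2)CC1`: 14300 nM
Compound 3 `CN1CCN(c2ccc(-c3cc4c(N5CCN(C(=O)Nc6ccc(Cl)c(C(F)(F)F)c6)CC5)ncnc4s3)cc2)CC1`: not yet measured

In a functional assay on MDA-MB-436 cells (Homo sapiens) for antiproliferative activity, read by MTT assay, with a stated time of 48 h (a lower number here means a stronger inhibitor, a higher number a weaker inhibitor), compound 2 has the higher of the two numbers, at 14300 nM. The next change is 4-chloro-3-(trifluoromethyl)phenyl in place of 2-fluorophenyl on an amide-type nitrogen. Within the data shown here, the only measured step at this place is a 2.9-fold higher number from compound 1 to compound 2 (0.46 log units; beyond the scatter), which is modest. Among the measured compounds shown here, with only this step as a guide, a modest move towards a lower number is expected, though the data leave the direction uncertain. The expected change is a 2.9-fold lower number from compound 2 to compound 3 (0.46 log units; beyond the scatter). For compound 3, the estimated value is 5000 nM, with an expected range of 1500 nM to 15000 nM.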

Compound 3, half-maximal inhibitory concentration: 3500 nM
Beside the measured number, compound 3's estimate is 1.4-fold (0.15 log units) above it; low and high end bracket the measured number.
By their numbers in this assay, from the lowest: compounds 3 and 1 (each within the scatter of the next); then compound 2.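

In this assay a second replacement of 2-fluorophenyl on the amide-type nitrogen also gives a lower number, with a 4.1-fold lower number from compound 2 to compound 3 (0.61 log units; beyond the scatter), so the higher number of compound 2 is not tied to 4-cyanophenyl alone as the comparison group. Against 4-cyanophenyl, the larger 4-chloro-3-(trifluoromethyl)phenyl gives a 1.4-fold lower number from compound 1 to compound 3 (0.16 log units; within the scatter), so these two groups cannot be separated at this position. Nothing available explains these differences.

From the compounds shown here alone, how a plain phenyl or a cyclohexyl group on this nitrogen would read in this assay stays open. Also open, going by these compounds, is whether any group here can give a number clearly lower than those of compound 1 and compound 3.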